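Compound 3: replacing furan-2-yl with 3,4-dimethylphenyl

A few compounds are considered here, and "the series" means these few. Any claim that something is new, unique, unknown or untested is made for them only; others in the source may bear on it.

Compounds measured so far in a functional assay on A549 cells (Homo sapiens) for antiproliferative activity, read by MTT assay; a higher number here means a weaker inhibitor, a lower number a stronger inhibitor:
Compound 1 `Cn1c(=O)c(=O)n(C2CCCC2)c2nc(N/N=C/c3ccc(S(C)(=O)=O)cc3)ncc21` gives 84500 nM
Compound 2 `Cn1c(=O)c(=O)n(C2CCCC2)c2nc(N/N=C/c3ccco3)ncc21` gives > 100000 nM (a limit)

Compound 2 stands at a limit of this assay and has no exact number, its entry being > 100000 nM as a limit only.

The next compound to be read is compound 3 `Cc1ccc(/C=N/Nc2ncc3c(n2)n(C2CCCC2)c(=O)c(=O)n3C)cc1C`. The change is 3,4-dimethylphenyl in place of furan-2-yl on a carbon with a double bond to nitrogen, so 3,4-dimethylphenyl brings back a six-membered aromatic ring of carbon only.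

Among the measured compounds shown here, one measured step bears on this change, at the same place on the carbon with a double bond to nitrogen. It is an at least 1.1-fold higher number from compound 1 to compound 2 (0.07 log units; that floor lies within the scatter), and it gives only a floor, so it fixes no real size for such a swap. For the measured compounds named here, compound 1, which carries 4-(methylsulfonyl)phenyl there, gives 84500 nM as the only exact number available, and it is the nearest guide for an aryl group at this place.

Compound 3 is therefore expected to read close to compound 1, with a modest move to a lower number or none beyond the scatter. The expected change is an at least 1.4-fold lower number from compound 2 to compound 3 (0.15 log units; that floor lies within the scatter), and its size is uncertain. For compound 3 the estimate is 70000 nM, with an expected range from 20000 nM to 150000 nM.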

Compound 3, half-maximal inhibitory concentration: 30200 nM
Beside the measured number, compound 3's estimate is 2.3-fold (0.37 log units) above it; the range from low to high includes it.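

In this assay, 3,4-dimethylphenyl in place of furan-2-yl on the carbon with a double bond to nitrogen gives a step that clears the scatter (an at least 3.3-fold lower number from compound 2 to compound 3 (0.51 log units; beyond the scatter)) while the earlier step at this place gave only a floor within the scatter. The two groups built on a six-membered aromatic ring of carbon only also come apart, with 3,4-dimethylphenyl in place of 4-(methylsulfonyl)phenyl moving the number beyond the scatter (a 2.8-fold lower number from compound 1 to compound 3 (0.45 log units; beyond the scatter)) so in this pair the reading depends on what that ring carries and not on the ring alone. The step from the furan-2-yl compound still gives no exact size and could be larger than its floor, because compound 2 has only a limit and no exact number: the limit of > 100000 nM in this assay, at which 1 of the 3 values shown sits.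

On these data alone, whether a single methyl group on the ring would give the same reading as 3,4-dimethylphenyl, and whether an amine or a carboxylic acid there would move the number further, stays open. What a change elsewhere on the shared core would do at this reading is equally unknown.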